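Pentyloxy to Cyclopentylamino: Expected Cell Tolerance

The source may report more compounds than this note shows. Statements on the series, on what has been measured and on what is new or still open speak of the compounds shown alone.

Compound 1 `CCCCCOc1nc(N)nc2c1ncn2/C=C1/CC1(CO)CO` is the starting point. In an ADME assay on CCRF-HSB-2 cells (Homo sapiens) for cytotoxicity, with a stated time of 7 days (a higher number here means that more compound is tolerated, a lower number that less compound is tolerated), compound 1 gives > 20000 nM, and that figure is a limit of the assay, not a number. Compound 2 `Nc1nc(N2CCCC2)c2ncn(/C=C3/CC3(CO)CO)c2n1` is its closest measured relative, carrying pyrrolidin-1-yl in place of pentyloxy on an aromatic carbon. In this assay compound 2 gives > 20000 nM, which is again only a limit. Compound 3 `Nc1nc2c(ncn2/C=C2/CC2(CO)CO)c(=O)[nH]1` is the third member of the set. In this assay compound 3 gives > 20000 nM, once more a limit. Among the compounds with values here, the single one-place step between measured compounds, a step that the two limits leave unreadable from compound 1 to compound 2, has a limit at each end and so carries no readable size. The whole picture is summed up by the limit of > 20000 nM in this assay, at which 3 of the 3 values shown sit: nothing in this set has yet shown measurable harm to the cells within the tested range.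

The new compound, compound 4 `Nc1nc(NC2CCCC2)c2ncn(/C=C3/CC3(CO)CO)c2n1`, differs from compound 1 by cyclopentylamino in place of pentyloxy on an aromatic carbon. Within the data shown here, the only comparable step, the swap at the same aromatic carbon from compound 1 to compound 2, stayed at the limit, so no change beyond the scatter is expected in this assay. Compound 4 is therefore estimated to give 30000 nM, within a range of 10000 nM to 100000 nM, and most probably the assay will again report only a limit. The step this estimate implies, a step that the limit leaves unreadable from compound 1 to compound 4, is expected to be no change of any readable size.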

Compound 4, half-maximal cytotoxic concentration: > 20000 nM
Compound 4: only a limit was reported (the forecaster's own chance of this, stated with the estimate: 85%); the middle value is on the limit's open side.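

The steps from compound 1 to compound 4 and from compound 2 to compound 4 have a limit at each end and cannot be read, and the whole set stays at one value: the limit of > 20000 nM in this assay, at which 4 of the 4 values shown sit. The compounds shown leave open at what concentration, if any, each would harm these cells, and whether pentyloxy, pyrrolidin-1-yl and cyclopentylamino would then differ.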